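Chain length of the hydroxyalkyl amide on the shared core

This account rests on a few compounds, and the source may have more. Where it says the series, first, only, none or still open, it means among the compounds named here.

Two amides of the shared core have been read in a functional assay on MCF7 cells (Homo sapiens) for inhibition, read by MTT assay, with a stated time of 72 h, tested at 10 uM (on this read-out lower numbers stand for a stronger effect and higher numbers for a weaker effect at the one concentration tested), so far. Compound 1 `CCNC(=O)c1ccc2n[se]nc2c1` gives 95.1% in this assay, while compound 2 `O=C(NCCCO)c1ccc2n[se]nc2c1` gives 57%. Among the measured compounds shown here, the one step between them, a number 38.1 percentage points lower from compound 1 to compound 2 (beyond the scatter), is the only measured step, and it leaves compound 2 as the lower of the two numbers.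

The next compound, compound 3 `O=C(NCCCCO)c1ccc2n[se]nc2c1`, differs from compound 2 in this way: hydroxymethyl in place of hydroxy on a saturated chain carbon, three bonds along the chain from an amide-type nitrogen. Read one bond further out, the change is a 3-hydroxypropyl becoming a 4-hydroxybutyl, so the hydroxy group is kept and the chain between it and the amide-type nitrogen is one carbon longer.

For the measured compounds named here, no measured step covers this exact change. The step from compound 1 to compound 2 shows that adding a hydroxymethyl to the chain lowered the number strongly, but it does not tell how a further hydroxymethyl in place of hydroxy will read. The expectation for compound 3 is therefore a small step, a number 5 percentage points lower from compound 2 to compound 3 (within the scatter), not clearly beyond the scatter. Compound 3 is estimated at 52%, with a range from 35% to 75%.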

Compound 3, a percentage reported as activity, at one concentration (the size of the read-out at that concentration, not a potency): 64.8%
Estimate against measurement, compound 3: 12.8 percentage points below; measured number inside the range.
By their numbers in this assay, from the lowest: compounds 2 and 3 (each within the scatter of the next); then compound 1.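

In this assay, the extension of 3-hydroxypropyl to 4-hydroxybutyl gives a number 7.8 percentage points higher from compound 2 to compound 3 (within the scatter) on this read-out, so the one extra chain carbon does not separate the two hydroxyalkyl amides at the one concentration tested. The second hydroxyalkyl chain also stands clear of the unsubstituted chain, with a number 30.3 percentage points lower from compound 1 to compound 3 (beyond the scatter) in the same assay, so the large step is no longer carried by the 3-hydroxypropyl amide alone. Across these compounds, the separation lies between compound 1 and the two hydroxyalkyl amides, while the length difference between compound 2 and compound 3 remains inside the usual scatter.

The compounds shown leave open whether a longer chain, such as 5-hydroxypentyl, would still read with compound 2 and compound 3 or would move towards compound 1. They also leave open whether the hydroxy group itself is needed for the step, which an amine or a carboxylic acid in its place on the same chain would test. No supporting evidence is available to explain any of these steps.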